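A few compounds are considered here, and "the series" means these few. Any claim that something is new, unique, unknown or untested is made for them only; others in the source may bear on it.

Compound 1 `C#CCN(CC)Cc1cn(-c2cc(NC(=S)NCC)ncn2)cn1` is the lower of the two numbers measured in an assay on isolated protein for inhibition of Amine oxidase [flavin-containing] B (Homo sapiens), read by fluorescence and Amplex Red, with a stated time of 15 min, tested at 50 uM (on this read-out higher numbers stand for more inhibition at the one concentration tested (going by the name of the read-out) and lower numbers for less inhibition), where compound 1 gives 35.1%. Compound 2 `C#CCN(CC#C)Cc1cn(-c2cc(NC(=S)NCC)ncn2)cn1` gives 42.1% in this assay, and the step of a number 7 percentage points higher from compound 1 to compound 2 (within the scatter) shows how little that change mattered. Compound 3 `C#CCN1CCN(Cc2cn(-c3cc(NC(=S)NCC)ncn3)cn2)CC1` has not yet been measured; it differs from compound 1 by 4-propargylpiperazin-1-yl in place of ethyl(propargyl)amino on a saturated chain carbon bound to an aromatic carbon. Going by the values given here, the only measured step, a number 7 percentage points higher from compound 1 to compound 2 (within the scatter), touches the same amine region but is a different, smaller change, so it gives weak guidance. The step of a number 0.1 percentage points lower from compound 1 to compound 3 (within the scatter) is therefore expected to stay within the scatter. Compound 3 is estimated to give 35%, between 10% and 60%.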

Compound 3, a percentage reported as inhibition, at one concentration (the size of the read-out at that concentration, not a potency): 13.3%
Beside the measured number, compound 3's estimate is 21.7 percentage points above it, within the range that was stated.
By their numbers in this assay, from the lowest: compound 3; then compounds 1 and 2 (each within the scatter of the next).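

In this assay the ring-bearing 4-propargylpiperazin-1-yl gives a number 21.8 percentage points lower from compound 1 to compound 3 (beyond the scatter) and a number 28.8 percentage points lower from compound 2 to compound 3 (beyond the scatter). Unlike the earlier swap on the open-chain amine, this shows that the group on the saturated chain carbon bound to an aromatic carbon can change the read-out beyond the scatter. No measurement shown bears on the cause of this drop. As far as these compounds go, whether the ring or its second nitrogen matters remains open. A piperidine or a morpholine at the same place would separate those two features.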